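Compound 3: swapping benzylsulfanyl for a lactam

The compounds below may be only part of what the source reports. "The series", "measured", "known", "first", "only" and "open" are said of these compounds alone.

The compounds measured so far in a functional assay on Huh-7 cells (Homo sapiens) for cytotoxicity, read by MTT assay, with a stated time of 3 days (on this read-out higher numbers stand for lower toxicity in this test and lower numbers for higher toxicity in this test), are these:
Compound 1 `CN(Cc1ncnc2c1ncn2[C@@H]1O[C@H](CO)[C@@H](O)[C@H]1O)c1ccccc1` gives 21000 nM
Compound 2 `OC[C@H]1O[C@@H](n2cnc3c(CSCc4ccccc4)ncnc32)[C@H](O)[C@@H]1O` gives > 100000 nM

Compound 2 reads > 100000 nM in this assay and this is a limit, not a number. Its standing is the limit of > 100000 nM in this assay, at which 1 of the 2 values shown sits, and nothing firmer can be said.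

Compound 3 `O=C1CCCN1Cc1ncnc2c1ncn2[C@@H]1O[C@H](CO)[C@@H](O)[C@H]1O` keeps the shared core and differs from compound 2 by 2-oxopyrrolidin-1-yl in place of benzylsulfanyl on a saturated chain carbon bound to an aromatic carbon.

Within the data shown here, one measured step bears on this place, an at least 4.7-fold higher number from compound 1 to compound 2 (0.67 log units; beyond the scatter) (benzylsulfanyl in place of methyl(phenyl)amino). Among the measured compounds shown here, it shows that a change here can move the read-out, yet no measured compound carries 2-oxopyrrolidin-1-yl. Both measured compounds hold a six-membered aromatic ring of carbon only, and compound 3 has none, so this comparison gives only weak guidance. No step beyond the scatter is therefore expected, and the value should stay near the limit.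

The step expected is a number no higher from compound 2 to compound 3 (the limit leaves the size open) in this estimate. For compound 3 the estimate is 100000 nM with an expected range from 30000 nM to 300000 nM and a report at the limit is likely.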

Compound 3, half-maximal cytotoxic concentration: 45000 nM
For compound 3 the middle estimate is 2.2-fold (0.35 log units) above the measured one; low and high end bracket the measured number.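

With compound 3, a group holding no six-membered aromatic ring of carbon only gives a firm number at this place, on a saturated chain carbon bound to an aromatic carbon, in this assay. The read-out shows an at least 2.2-fold lower number from compound 2 to compound 3 (0.34 log units; beyond the scatter), and also a 2.1-fold higher number from compound 1 to compound 3 (0.33 log units; beyond the scatter). Compounds 1 and 2 both hold that aromatic ring yet fall on opposite sides of compound 3, so among these three compounds, the presence of that ring does not by itself set the read-out. The true size of the step from compound 2 stays open because compound 2 gives only a limit and not a number: the limit of > 100000 nM in this assay, at which 1 of the 3 values shown sits.

The compounds shown leave open how a plain amine, a carboxylic acid or a longer saturated chain would read at this place. They also leave open whether the ring of 2-oxopyrrolidin-1-yl or its carbonyl matters to the read-out, since an open-chain amide or a pyrrolidine ring without the carbonyl is not among them.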